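The source may hold more compounds than are shown below. What is called first, only, known or untested is meant among the compounds shown, and "the series" means these compounds.

compound 1 `[O-][n+]1onc2cc(/C=C\c3ccccc3)ccc21` gives 62600 nM
compound 2 `[O-][n+]1onc2cc(/C=C/c3ccc(Cl)cc3)ccc21` gives > 200000 nM

In an ADME assay on THP-1 cells (Homo sapiens) for cytotoxicity, with a stated time of 48 h (a higher number here means a weaker inhibitor, a lower number a stronger inhibitor), compound 2 reaches only a limit (> 200000 nM), and no exact number is known for it. Among the compounds with values here, compound 3 `[O-][n+]1onc2cc(/C=C\c3ccc(Cl)cc3)ccc21` has the same atoms and bonds as compound 2 (the two compounds have the same atoms and bonds and differ only in configuration as drawn: 1 of 1 stereo elements differ; a double bond is drawn E in compound 2 and Z in compound 3), with the double bond drawn Z instead of E. The expectation leans on compound 1 (62600 nM), the only exact number available. An estimated step of an at least 2.5-fold lower number from compound 2 to compound 3 (0.39 log units; beyond the scatter) is expected toward a stronger inhibitor, beyond the scatter. For compound 3 the expected value is 80000 nM (estimated range 25000 nM to 200000 nM).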

Compound 3, half-maximal inhibitory concentration: 97000 nM
Compound 3: middle estimate off by 1.2-fold (0.08 log units), on the low side; the measured number falls inside the stated range.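

Within this assay the pair of compound 2 and compound 3 isolates the double bond, and going from E to Z gives an at least 2.0-fold lower number from compound 2 to compound 3 (0.31 log units; beyond the scatter) in the chloro series. Compound 2 holds only a limit, so this step has no exact size: the limit of > 200000 nM in this assay, at which 1 of the 3 values shown sits. On the Z double bond, chloro in place of hydrogen on an aromatic carbon gives a 1.5-fold higher number from compound 1 to compound 3 (0.19 log units; within the scatter) and so does not separate the two compounds. Going by these compounds, it remains open whether the E double bond without chloro would also reach the limit, and whether a methoxy group or an amine in place of chloro would behave like chloro.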